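A few compounds are considered here, and "the series" means these few. Any claim that something is new, unique, unknown or untested is made for them only; others in the source may bear on it.

Measured in an ADME assay on cells (Fibroblast, Homo sapiens) for cytotoxicity, read by cell counting, with a stated time of 48 h; a higher number here means a weaker inhibitor, a lower number a stronger inhibitor:
- compound 1 `Cc1ccc(-n2cc(COc3cccc4cnc(Nc5cccc(Cl)c5)nc34)nn2)c([N+](=O)[O-])c1` gives 21000 nM
- compound 2 `Clc1ccc(-n2cc(COc3cccc4cnc(Nc5cccc(Cl)c5)nc34)nn2)cc1` gives > 25000 nM
- compound 3 `Clc1cccc(Nc2ncc3cccc(OCc4cn(-c5ccc(Br)cc5)nn4)c3n2)c1` gives > 25000 nM

In this assay compound 2 returns only a limit of the assay, not a number. Compound 3 likewise returns only a limit. Two of the three values therefore sit at the same limit (the limit of > 25000 nM in this assay, at which 2 of the 3 values shown sit), and only compound 1 gives a definite number. The step from compound 1 to compound 2 is an at least 1.1-fold higher number from compound 1 to compound 2 (0.07 log units; that floor lies within the scatter), and the step from compound 1 to compound 3 is an at least 1.1-fold higher number from compound 1 to compound 3 (0.07 log units; that floor lies within the scatter); both floors stay within the scatter. Between compound 2 and compound 3 the step is a step that the two limits leave unreadable from compound 2 to compound 3.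

Compound 4 `Clc1cccc(Nc2ncc3cccc(OCc4cn(-c5cc(Cl)cc(Cl)c5)nn4)c3n2)c1` differs from compound 2 by 3,5-dichlorophenyl in place of 4-chlorophenyl on an aromatic nitrogen. The nearest comparison is the swap of one halogen for another from compound 2 to compound 3, which the two limits leave unreadable; the other steps show nothing beyond the scatter. No step beyond the scatter is expected in this assay, so compound 4 is expected to stay near the limit at 30000 nM, within 12000 nM to 80000 nM. The expected step is a step that the limit leaves unreadable from compound 2 to compound 4.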

Compound 4, half-maximal inhibitory concentration: 8000 nM
Beside the measured number, compound 4's estimate is 3.8-fold (0.57 log units) above it; measured number outside the range, below it.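

Within the data shown here, on the aromatic nitrogen of the five-membered ring, 3,5-dichlorophenyl is the first group to bring a change in this assay that lies beyond the scatter, with an at least 3.1-fold lower number from compound 2 to compound 4 (0.49 log units; beyond the scatter) and an at least 3.1-fold lower number from compound 3 to compound 4 (0.49 log units; beyond the scatter). Among these compounds, the same group also gives a 2.6-fold lower number from compound 1 to compound 4 (0.42 log units; beyond the scatter), so it moves past the only definite number among the earlier compounds, and the cells respond to this group at a lower concentration. The first two steps are only floors, and their full size stays unknown, because two of the values stop at a limit: the limit of > 25000 nM in this assay, at which 2 of the 4 values shown sit.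

From the compounds shown here alone, it remains open whether a single chlorine in 3-chlorophenyl would give a similar step, or whether both chlorines are needed. Also open, going by these compounds, is how the number would shift with an amine or a carboxylic acid on this phenyl ring.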